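Acetyl to dimethylamino on the phenyl ring of compound 1

The compounds below may be only part of what the source reports. "The series", "measured", "known", "first", "only" and "open" are said of these compounds alone.

Measured compounds:
compound 1, `COc1cc(C)cc(-c2c(-c3ccnc(-c4ccc(C(C)=O)cc4)c3)cnn2CC#N)c1`: 91%
compound 2, `COc1cc(C)cc(-c2nn(CC#N)cc2-c2ccc(-c3cccc(C(C)=O)c3)nc2)c1`: 93%
compound 3, `Cc1cc(O)cc(-c2nn(CC#N)cc2-c2ccnc(-c3ccc(N(C)C)cc3)c2)c1`: 98%

Of the compounds shown here, three sharing a common core have been tested in a functional assay on HCT-116 cells (Homo sapiens) for cytotoxicity, read by sulforhodamine B assay, with a stated time of 48 h, tested at 0.01 uM; on this read-out lower numbers stand for a stronger effect and higher numbers for a weaker effect at the one concentration tested. Compound 1 gives 91% in this assay, compound 2 gives 93%, and compound 3 gives 98%. The number of compound 1 differs from that of compound 2 and from that of compound 3 only within the scatter of this assay, so the three measurements cannot be told apart, and all of them indicate only a weak effect at the single concentration tested.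

Compound 4, `COc1cc(C)cc(-c2c(-c3ccnc(-c4ccc(N(C)C)cc4)c3)cnn2CC#N)c1`, has not yet been measured in this assay. It is derived from compound 1 by one change:

dimethylamino in place of acetyl on an aromatic carbon

Among the measured compounds shown here, no pair of measured compounds differs in just this one place, so the size of this step is not known from the data. Compound 3, which also carries a dimethylamino group on its phenyl ring, gives 98%, a number indistinguishable within the scatter from that of compound 1. On that basis the step of a number 4 percentage points higher from compound 1 to compound 4 (within the scatter) is expected to stay within the scatter. Compound 4 is therefore estimated at 95% in this assay, with a range from 85% to 103%.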

Compound 4, a percentage reported as activity, at one concentration (the size of the read-out at that concentration, not a potency): 44%
Compound 4: middle estimate off by 51 percentage points, on the high side; measured number outside the range, below it.
By their numbers in this assay, from the lowest: compound 4; then compounds 1, 2 and 3 (each within the scatter of the next).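

Replacing 4-acetylphenyl with 4-(dimethylamino)phenyl produces a number 47 percentage points lower from compound 1 to compound 4 (beyond the scatter) in this assay and shows that the group at this place, para to a large group, can strongly change the read-out at the one concentration tested. The earlier compounds could not show this, since their numbers lay within the scatter of one another and no two of them differed in one place only; here, the groups that leave and enter have the same count of heavy atoms and of hydrogen-bond acceptors, so those counts do not account for the difference. Nothing measured here explains the size of this step.

On these data alone, it remains open whether the change depends on dimethylamino itself or would also appear with a primary amine, a methoxy group or a pyrrolidine ring at the same place. It is also unknown whether the same exchange would give a step of similar size on the core of compound 2, or whether the stronger effect of compound 4 at the one concentration tested would also be seen at other concentrations.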